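The source may report more compounds than this note shows. Statements on the series, on what has been measured and on what is new or still open speak of the compounds shown alone.

Measured compounds:
compound 1, `C=C1CC[C@@H]2[C@](C)(CO)[C@H](O)CC[C@@]2(C)[C@@H]1C/C=C1/C(=O)OC[C@H]1OC(=O)CCCSc1ccc(OC)cc1`: 19000 nM
compound 2, `C=C1CC[C@@H]2[C@](C)(CO)[C@H](O)CC[C@@]2(C)[C@@H]1C/C=C1/C(=O)OC[C@H]1OC(=O)CCCSc1ccc(F)cc1`: 12000 nM

In a functional assay on PC-3 cells (Homo sapiens) for inhibition, read by MTT assay, with a stated time of 48 h (a higher number here means a weaker inhibitor, a lower number a stronger inhibitor), compound 1 gives 19000 nM, and in this assay compound 2 gives 12000 nM. For the measured compounds named here, compound 2 has the lower of the two numbers, but the only step measured so far, a 1.6-fold lower number from compound 1 to compound 2 (0.20 log units; within the scatter), is within the scatter, so the two compounds cannot be told apart on these data.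

Compound 3, `C=C1CC[C@@H]2[C@](C)(CO)[C@H](O)CC[C@@]2(C)[C@@H]1C/C=C1/C(=O)OC[C@H]1OC(=O)CCCSc1ccccn1`, differs from compound 2 by pyridin-2-yl in place of 4-fluorophenyl on a sulfur. Going by the values given here, no measured step involves this change; the single step in hand concerns a substituent on the aromatic ring, not the ring itself, and it was within the scatter. There is therefore no basis for expecting a step beyond the scatter, and the expected step of no change at the digits printed from compound 2 to compound 3 (within the scatter) reflects that. For compound 3 the estimate is 12000 nM, with a range from 5000 nM to 30000 nM.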

Compound 3, half-maximal inhibitory concentration: 14000 nM
Beside the measured number, compound 3's estimate is 1.2-fold (0.07 log units) below it; the measured number falls inside the stated range.
By their numbers in this assay, from the lowest: compounds 2, 3 and 1 (each within the scatter of the next).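

In this assay, for the compounds shown here, the aromatic ring on the sulfur was itself changed for the first time, not just a substituent on it. Pyridin-2-yl in place of 4-fluorophenyl gives a 1.2-fold higher number from compound 2 to compound 3 (0.07 log units; within the scatter), and pyridin-2-yl in place of 4-methoxyphenyl gives a 1.4-fold lower number from compound 1 to compound 3 (0.13 log units; within the scatter). So at this position, a ring with one hetero atom and one hydrogen-bond acceptor leaves the number within the scatter of both compounds with a carbon-only ring, and nothing available explains this result.

All three compounds lie within the scatter of one another, so no change at this position has yet been shown to move the number. Going by these compounds, it remains open whether an amine or a carboxylic acid on the aromatic ring, or a longer chain carrying the sulfur, would give a step beyond the scatter.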